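The source may report more compounds than this note shows. Statements on the series, on what has been measured and on what is new or still open speak of the compounds shown alone.

In a functional assay on MDA-MB-231 cells (Homo sapiens) for cytotoxicity, read by MTT assay, with a stated time of 48 h (a higher number here means a weaker inhibitor, a lower number a stronger inhibitor), compound 1 `COc1cc(-n2c(-c3ccc(Cl)cc3)csc2=S)cc(OC)c1OC` gives > 100 ug/mL as a limit of the assay, not a number. Compound 2 `COc1cc(-n2c(-c3ccc(-c4ccccc4)cc3)csc2=S)cc(OC)c1OC` gives > 100 ug/mL as a limit too. So all that is known so far is the limit of > 100 ug/mL in this assay, at which 2 of the 2 values shown sit, and no exact value exists to build on. Within the data shown here, the only measured step is a step that the two limits leave unreadable from compound 1 to compound 2 and it swaps chloro for phenyl, so it offers no size to carry over. Compound 3 `COc1cc(-n2c(-c3ccc(O)c(O)c3)csc2=S)cc(OC)c1OC` differs from compound 1 by 3,4-dihydroxyphenyl in place of 4-chlorophenyl on an aromatic carbon and this places 3,4-dihydroxyphenyl in place of 4-chlorophenyl on an aromatic carbon. With so little to go on, only a modest shift towards a stronger inhibitor is expected, and no shift at all remains quite possible. The expected change is an at least 1.2-fold lower number from compound 1 to compound 3 (0.09 log units; that floor lies within the scatter) and it is a cautious estimate. Compound 3 is estimated at 80 ug/mL in this assay with an expected range from 25 ug/mL to 150 ug/mL as its likely span.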

Compound 3, half-maximal inhibitory concentration: 29.8 ug/mL
Beside the measured number, compound 3's estimate is 2.7-fold (0.43 log units) above it, within the range that was stated.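

Swapping 4-chlorophenyl for 3,4-dihydroxyphenyl gives the first readable change at this position, on the aromatic carbon next to the ring nitrogen, in this assay: an at least 3.3-fold lower number from compound 1 to compound 3 (0.52 log units; beyond the scatter). The earlier pair could not show that this position responds at all, whereas this step shows that the group placed here can change the read-out by more than the usual scatter. The size is only a floor, the true gap may be wider, and exact numbers remain scarce: the limit of > 100 ug/mL in this assay, at which 2 of the 3 values shown sit.

The compounds shown leave open whether a 4-hydroxyphenyl group alone would give a step of this size, or whether both hydroxyl groups of 3,4-dihydroxyphenyl are needed. Going by these compounds, how a phenyl ring bearing an amine or a carboxylic acid would read in this assay also remains open.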